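A few compounds are considered here, and "the series" means these few. Any claim that something is new, unique, unknown or untested is made for them only; others in the source may bear on it.

Compound 1 `O=C(O)c1ccc(COc2cccc(/C=C3\SC(=S)N(c4ccccc4)C3=O)c2)cc1` in an assay on isolated protein for inhibition of Apoptosis regulator Bcl-2 (Homo sapiens), read by fluorescence polarization (a higher number here means a weaker inhibitor, a lower number a stronger inhibitor), gives > 10000 nM, which is a limit of the assay. Compound 2 `Cc1cccc(N2C(=O)/C(=C/c3ccc(OCC(=O)Nc4ccc(C(=O)O)cc4)cc3)SC2=S)c1` in this assay gives > 10000 nM, also a limit. Compound 3 `Cc1ccc(N2C(=O)/C(=C/c3ccc(OCc4ccc(C(=O)O)cc4)cc3)SC2=S)cc1` in this assay gives > 10000 nM, again a limit.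

Compound 3 thus stands at the limit of > 10000 nM in this assay, at which 3 of the 3 values shown sit, and no number sets it apart from the other two measured compounds. Compound 4 `O=C(O)c1ccc(COc2ccc(/C=C3\SC(=S)N(c4ccc(Br)cc4)C3=O)cc2)cc1` differs from compound 3 by a single change: bromo in place of methyl on an aromatic carbon. No pair of measured compounds shows a step of this kind in this assay, so the expected step from compound 3 to compound 4 is a step that the limit leaves unreadable from compound 3 to compound 4, nothing beyond the usual scatter. Compound 4 is therefore expected near 15000 nM, between 5000 nM and 50000 nM, most likely reported only as a limit.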

Compound 4, inhibition constant: 610 nM
Compound 4: middle estimate off by 25-fold (1.39 log units), on the high side; the whole stated range lies above it.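

In this assay, within the data shown here, 4-bromophenyl in place of 4-methylphenyl brings an at least 16-fold lower number from compound 3 to compound 4 (1.21 log units; beyond the scatter), so a swap of one heavy atom at this place, on an aromatic carbon para to a large group, is enough to give the first value here that can be read as a number. The value of compound 3 is only a limit of the assay, so the true size of this step remains unknown: the limit of > 10000 nM in this assay, at which 3 of the 4 values shown sit.

The compounds shown leave open whether bromo is special here or whether another group, such as chloro, methoxy or an amine, would serve as well.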